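From a Fluoro Group to an Imidazole Ring

This account rests on a few compounds, and the source may have more. Where it says the series, first, only, none or still open, it means among the compounds named here.

Compound 1 `COc1ccc(C(=O)/C=C/c2ccc(F)cc2)c2c1C=CC(C)(C)O2`: > 10000 nM, a limit of the assay rather than a number.
Compound 2 `COc1ccc(C(=O)/C=C/c2ccc3ccccc3c2)c2c1C=CC(C)(C)O2`: 7650 nM.

Both were tested in a functional assay on SK-OV-3 cells (Homo sapiens) for antiproliferative activity, read by MTT assay, with a stated time of 24 h; a higher number here means a weaker inhibitor, a lower number a stronger inhibitor. For compound 1 the outcome is only a limit: in this assay compound 1 gives > 10000 nM, which is the limit of > 10000 nM in this assay, at which 1 of the 2 values shown sits, so where compound 1 stands is known only as being at that limit, without a number of its own. In this assay compound 2 gives 7650 nM, a measured number at the weak end of the scale. For the measured compounds named here, the two compounds differ at more than one place, so no single step between them can be drawn.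

Compound 3 `COc1ccc(C(=O)/C=C/c2ccc(-n3ccnc3)cc2)c2c1C=CC(C)(C)O2` differs from compound 1 in one place: 1H-imidazol-1-yl in place of fluoro on an aromatic carbon. Going by the values given here, no measured pair shows the effect of this particular exchange, so the expectation rests only on the weak inhibition seen so far. The step is expected to be small, if anything toward stronger inhibition, and is estimated as an at least 1.4-fold lower number from compound 1 to compound 3 (0.15 log units; that floor lies within the scatter). Compound 3 is expected at about 7000 nM, within a range of 2000 nM to 30000 nM.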

Compound 3, half-maximal inhibitory concentration: 7200 nM
Beside the measured number, compound 3's estimate is 1.0-fold (0.01 log units) below it; the measured number falls inside the stated range.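

Putting 1H-imidazol-1-yl in place of fluoro on this aromatic carbon, para to a large group, replaces a limit with a measured number, and the step is an at least 1.3-fold lower number from compound 1 to compound 3 (0.14 log units; that floor lies within the scatter). A single fluorine gives way here to a group of 5 heavy atoms with a five-membered aromatic ring of its own, and this assay still yields a number at the weak end of the scale, so this position can carry a much larger group, though the floor of the step does not show a real gain in inhibition. The true size of the step stays unknown, and only a floor can be given because compound 1 has a limit rather than a number of its own: the limit of > 10000 nM in this assay, at which 1 of the 3 values shown sits.

The compounds shown leave open whether an amine or a carboxylic acid on this same carbon would give a clearly lower number than compound 3. They also cannot tell whether the nitrogen atoms of 1H-imidazol-1-yl matter at all, a question that a phenyl ring at this position could help to settle.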